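Series notes: same change made on a second core

A few compounds are considered here, and "the series" means these few. Any claim that something is new, unique, unknown or untested is made for them only; others in the source may bear on it.

Measured:
compound 1 `C=CCn1c(SCC(=O)Nc2ccc(C(C)=O)cc2)nnc1-c1ccccc1` — 52%
compound 2 `C=CCn1c(SCC(=O)Nc2ccc(/C(C)=N/O)cc2)nnc1-c1ccccc1` — 63%
compound 3 `C=CCn1c(SCC(=O)Nc2ccc(C(C)=O)cc2)nnc1-c1ccc(OC)c(OC)c1` — 57%

In a functional assay on the whole organism (strain albino) for inhibition, with Rattus norvegicus as the target, read by paw edema, with stated times of 30 min and 2 h, at a dose of 0.28 mmol/kg by the oral route (a higher number here means more inhibition at the dose given (going by the name of the read-out), a lower number less inhibition), compound 1 gives 52%, compound 2 gives 63% and compound 3 gives 57%. The change from compound 1 to compound 2 is a group of 4 heavy atoms (2 carbon, 1 nitrogen, 1 oxygen; no ring) in place of a group of 3 heavy atoms (2 carbon, 1 oxygen; no ring), on an aromatic carbon, and it gave a number 11 percentage points higher from compound 1 to compound 2 (beyond the scatter). The two cores differ by 3,4-dimethoxyphenyl in place of phenyl on an aromatic carbon, with a number 5 percentage points higher from compound 1 to compound 3 (within the scatter).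

Compound 4 `C=CCn1c(SCC(=O)Nc2ccc(/C(C)=N/O)cc2)nnc1-c1ccc(OC)c(OC)c1` is not yet measured. It differs from compound 3 by a group of 4 heavy atoms (2 carbon, 1 nitrogen, 1 oxygen; no ring) in place of a group of 3 heavy atoms (2 carbon, 1 oxygen; no ring), on an aromatic carbon, the same change as from compound 1 to compound 2, at the same place. For the measured compounds named here, a similar step is expected, a number 11 percentage points higher from compound 3 to compound 4 (beyond the scatter), resting on the single earlier pair and on compound 3 standing at 57%; with one pair only, the expectation is loose. The estimate for compound 4 in this assay is 68%, expected between 55% and 80%.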

Compound 4, a percentage reported as inhibition, in the whole organism at one dose (the size of the read-out at that dose, not a potency): 56%
The estimate for compound 4 lay 12 percentage points above the measured number; measured number inside the range.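

In this assay, replacing acetyl on the 3,4-dimethoxyphenyl core gives a number 1 percentage points lower from compound 3 to compound 4 (within the scatter), and the two steps for this change cannot be told apart: the same change on two cores in this assay, a number 11 percentage points higher (beyond the scatter) from compound 1 to compound 2 and a number 1 percentage points lower (within the scatter) from compound 3 to compound 4, 12 percentage points apart, within the scatter of two such steps The 3,4-dimethoxyphenyl swap, made with the acetyl replacement in place, gives a number 7 percentage points lower from compound 2 to compound 4 (within the scatter), and this too matches its earlier step within the scatter: the same change on two cores in this assay, a number 5 percentage points higher (within the scatter) from compound 1 to compound 3 and a number 7 percentage points lower (within the scatter) from compound 2 to compound 4, 12 percentage points apart, within the scatter of two such steps The rise seen on the first core is therefore not shown to carry over to the second, yet no dependence on the core is shown either, since each comparison rests on a single pair at a single dose.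

As far as these compounds go, it remains open whether an amine or a carboxylic acid in place of acetyl would give a step beyond the scatter on both cores. Potency also remains open, as the read-out gives only the size of the effect at one dose.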